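Swapping the Amino Ring for a Dichloro Ring

The source may hold more compounds than are shown below. What is called first, only, known or untested is meant among the compounds shown, and "the series" means these compounds.

Compound 1 `COC(=O)C1=C(C)N=C(C)/C(=C(\O)OC)C1c1cccc(N)c1` was tested in a functional assay (muscle tissue) with Cavia porcellus as the target (on this read-out lower numbers stand for an effect already at smaller amounts and higher numbers for an effect only at larger amounts of compound), where compound 1 gives 2000 nM. Two companions share its core and differ only in the group carried on the aromatic ring. Compound 2 `COC(=O)C1=C(C)N=C(C)/C(=C(\O)OC)C1c1cccc(OC(C)=O)c1` gives 6030 nM, and compound 3 `COC(=O)C1=C(C)N=C(C)/C(=C(\O)OC)C1c1cccc([N+](=O)[O-])c1` gives 3.98 nM. Among these three numbers compound 1 stands second highest: the step of a 3.0-fold higher number from compound 1 to compound 2 (0.48 log units; beyond the scatter) is modest, whereas the step of a 500-fold lower number from compound 1 to compound 3 (2.70 log units; beyond the scatter) is large, and the step of a 1500-fold lower number from compound 2 to compound 3 (3.18 log units; beyond the scatter) is larger still. Compound 4 `COC(=O)C1=C(C)N=C(C)/C(=C(\O)OC)C1c1ccc(Cl)cc1Cl` has not yet been measured. Its change from compound 1 is 2,4-dichlorophenyl in place of 3-aminophenyl on a saturated ring carbon. Within the data shown here, none of the measured steps introduces a chlorine-bearing ring, so no step bears directly on this change. What the three steps do show is that exchanging the group on the aromatic ring can move the number over a very wide span, and that removing the amino group, as in the step from compound 1 to compound 3, went with a large drop. Compound 4 also loses that amino group, so a lower number than compound 1 is expected. The expected step for compound 4 is estimated as a 67-fold lower number from compound 1 to compound 4 (1.82 log units; beyond the scatter), sizeable but uncertain. The estimate for compound 4 is 30 nM, within a range from 3 nM to 300 nM.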

Compound 4, half-maximal effective concentration: 640 nM
The estimate for compound 4 lay 21-fold (1.33 log units) below the measured number; the measured number lies above the stated range.
By their numbers in this assay, from the lowest: compound 3; then compound 4; then compound 1; then compound 2.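

Replacing 3-aminophenyl with 2,4-dichlorophenyl on this saturated ring carbon of the shared core gives only a modest change in this assay: a 3.1-fold lower number from compound 1 to compound 4 (0.49 log units; beyond the scatter). The earlier compounds shown here left open whether the large drop with the nitro group reflected the loss of the amino group, but here the amino group is gone and the step is far smaller than a 500-fold lower number from compound 1 to compound 3 (2.70 log units; beyond the scatter), so losing that group does not by itself bring a drop of that size. This position therefore responds very differently to different aromatic groups that lack the amino group, with compound 4 at 640 nM still well above compound 3 at 3.98 nM, although nothing available here explains the size of either step.

Because the amino group leaves and two chlorines enter in a single step, the compounds shown cannot separate what each part of the change contributes. A plain phenyl ring would give the missing reference point, and a phenyl ring carrying a single chlorine, a methoxy group or a carboxylic acid would show how far the number at this position follows the group that the ring carries.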